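A trifluoromethyl group on compound 2

The source may report more compounds than this note shows. Statements on the series, on what has been measured and on what is new or still open speak of the compounds shown alone.

Compound 1 `COc1cc(/C=C/c2ccc(C)cc2)c(-c2ccccc2)c(OC)c1OC`: 45000 nM
Compound 2 `C=C(c1ccccc1)c1cc(OC)c(OC)c(OC)c1-c1ccccc1`: 42000 nM

In a functional assay on HeLa cells (Homo sapiens) for cytotoxicity, read by MTT assay, with a stated time of 48 h (a lower number here means a stronger inhibitor, a higher number a weaker inhibitor), compound 2 gives 42000 nM, which matches compound 1 within the scatter. Compound 3 `C=C(c1ccc(C(F)(F)F)cc1)c1cc(OC)c(OC)c(OC)c1-c1ccccc1` has trifluoromethyl in place of hydrogen on an aromatic carbon, para to a large group (trifluoromethyl in place of hydrogen on an aromatic carbon). Within the data shown here, the only measured step, a 1.1-fold lower number from compound 1 to compound 2 (0.03 log units; within the scatter), lies within the scatter and concerns a different change, so no measurement shows what trifluoromethyl does here. The expected change is therefore none beyond the scatter, with the estimated step of a 1.2-fold lower number from compound 2 to compound 3 (0.08 log units; within the scatter). For compound 3 the estimated value is 35000 nM, with an expected range from 14000 nM to 80000 nM.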

Compound 3, half-maximal inhibitory concentration: 32000 nM
Compound 3: middle estimate off by 1.1-fold (0.04 log units), on the high side; measured number inside the range.
By their numbers in this assay, from the lowest: compounds 3, 2 and 1 (each within the scatter of the next).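

In this assay, among these compounds, the change from phenyl to 4-(trifluoromethyl)phenyl gives a 1.3-fold lower number from compound 2 to compound 3 (0.12 log units; within the scatter), the first reading of a change at this position. Trifluoromethyl para to a large group is thus tolerated here, with no shift beyond the scatter in this one pair. No measurement bears on why the number stays put. The compounds shown leave open whether an amine or a carboxylic acid in the same place would move the number beyond the scatter.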